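The source may hold more compounds than are shown below. What is called first, only, known or untested is meant among the compounds shown, and "the series" means these compounds.

Within the data shown here, in a physicochemical assay for solubility, read by nephelometry, measured as kinetic solubility, with a stated time of 30 min, at pH 2.0 (on this read-out higher numbers stand for higher solubility and lower numbers for lower solubility), compound 2 (`O=C(O)COc1ccc([C@H]2CC[C@]3(CC2)OOC2(O3)C3CC4CC(C3)CC2C4)cc1`) gives 6.3 ug/mL as the only true number so far. Compound 1 (`O=C(O)c1cc([C@H]2CC[C@]3(CC2)OOC2(O3)C3CC4CC(C3)CC2C4)ccc1O`) also has a carboxy on an aromatic carbon, and its > 100 ug/mL is a limit, not a number. Measured against the limit of > 100 ug/mL in this assay, at which 1 of the 2 values shown sits, compound 2 stands low.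

Compound 3 (`O=C(O)COc1ccc([C@H]2CC[C@]3(CC2)OOC2(O3)C3CC4CC(C3)CC2C4)cc1C(=O)O`) differs from compound 2 by carboxy in place of hydrogen on an aromatic carbon as a carboxy in place of hydrogen on an aromatic carbon, ortho to a carboxymethoxy group and meta to a large group. Among the measured compounds shown here, no two measured compounds differ in one place only, so this change has no direct precedent here.

A moderate rise in this assay is expected, beyond the usual scatter but far from certain. That expectation rests only on compound 1 with its > 100 ug/mL as a limit. The expected step of a 4.0-fold higher number from compound 2 to compound 3 (0.60 log units; beyond the scatter) is therefore upward, although the low end of the estimate allows no real change at all. Compound 3 is estimated at 25 ug/mL with an expected range from 6 ug/mL to 100 ug/mL on this read-out.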

Compound 3, solubility: > 100 ug/mL
Compound 3: only a limit was reported; the forecaster's own chance of this, stated with the estimate: 20%; middle value at least 4.0-fold (0.60 log units) from the limit.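

Among these compounds, compound 2 and compound 3 differ in one place only, so this is the first change in the set that can be read directly: a carboxy in place of hydrogen on an aromatic carbon, ortho to a carboxymethoxy group and meta to a large group, gives an at least 15-fold higher number from compound 2 to compound 3 (1.20 log units; beyond the scatter). In this assay compound 3 gives > 100 ug/mL, which is a limit of the assay and not a number. The printed step is therefore a minimum rather than a true size, and the top of the read-out now limits what can be compared among these compounds: the limit of > 100 ug/mL in this assay, at which 2 of the 3 values shown sit.

The step between compound 1 and compound 3 cannot be read, since both compounds sit at that limit, so the set cannot rank the two carboxy-bearing compounds against each other. As far as these compounds go, it also remains open whether the rise depends on the carboxy itself or would also appear with a different group at the same place, such as an amine or a primary amide, and a comparison of that kind would need values that fall inside the range of the read-out.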